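This account rests on a few compounds, and the source may have more. Where it says the series, first, only, none or still open, it means among the compounds named here.

In a functional assay on A549 cells (Homo sapiens) for inhibition, read by MTT assay, with a stated time of 72 h (on this read-out higher numbers stand for weaker inhibition and lower numbers for stronger inhibition), compound 2 (`O=C(CCCCCCCN(Cc1ccc(F)cc1)c1ncc(C(=O)NCCCn2ccnc2)s1)NO`) gives 6600 nM, the middle of the three numbers, with compound 3 (`O=C(/C=C/c1ccc(CN(Cc2ccc(F)cc2)c2ncc(C(=O)NCCCn3ccnc3)s2)cc1)NO`) lower at 2700 nM and compound 1 (`CC(C)CCN(CCCCCCC(=O)NO)c1ncc(C(=O)NCc2cccnc2)s1`) higher at 19000 nM. Compound 4 (`O=C(CCCCCN(Cc1ccc(F)cc1)c1ncc(C(=O)NCCCn2ccnc2)s1)NO`) is compound 2 with one change: hydroxycarbamoyl in place of 2-(hydroxycarbamoyl)ethyl on a saturated chain carbon, five bonds along the chain from a nitrogen on an aromatic ring. Going by the values given here, the only measured step at this chain is a 2.4-fold lower number from compound 2 to compound 3 (0.39 log units; beyond the scatter), a modest one, and it replaces the whole 6-(hydroxycarbamoyl)hexyl rather than shortening it. Among the compounds with values here, compound 1 differs in more than one place, and no measured pair isolates chain length, so the direction in this assay stays open. A step no larger than that modest one is expected, most likely none beyond the scatter. The expected change is a 1.1-fold higher number from compound 2 to compound 4 (0.03 log units; within the scatter). For compound 4 the estimated value is 7000 nM, within an expected range of 2500 nM to 20000 nM.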

Compound 4, half-maximal inhibitory concentration: 54000 nM
Compound 4: middle estimate off by 7.7-fold (0.89 log units), on the low side; the measured number lies above the stated range.
By their numbers in this assay, from the lowest: compound 3; then compound 2; then compound 1; then compound 4.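

In this assay, chain length at this position now has a measured effect: an 8.2-fold higher number from compound 2 to compound 4 (0.91 log units; beyond the scatter), with hydroxycarbamoyl replacing 2-(hydroxycarbamoyl)ethyl. The position is therefore sensitive to shortening, and the wider gap appears against the aryl linker, with a 20-fold higher number from compound 3 to compound 4 (1.30 log units; beyond the scatter) when 4-(hydroxycarbamoyl)butyl replaces 4-(2-(hydroxycarbamoyl)ethenyl)phenyl. No supporting data are available to explain either step. The compounds shown leave open whether the trend continues or reverses with a longer chain than 6-(hydroxycarbamoyl)hexyl. They also leave open how a carboxylic acid in place of hydroxycarbamoyl would read here.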